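This account rests on a few compounds, and the source may have more. Where it says the series, first, only, none or still open, it means among the compounds named here.

Compound 1 `O=C(O)CCCn1c2ccc([N+](=O)[O-])cc2c(=O)n1Cc1ccccc1`: "not determined" (no result reported)
Compound 2 `O=[N+]([O-])c1ccc2nn(Cc3ccccc3)c(OCCBr)c2c1`: "not determined" (no result reported)
Compound 3 `O=[N+]([O-])c1ccc2nn(Cc3ccccc3)c(OCCCBr)c2c1`: 539000 nM

These entries come from an ADME assay on Vero cells (Chlorocebus sabaeus) for inhibition, read by fluorescence and resazurin assay, with a stated time of 24 h; on this read-out higher numbers stand for lower toxicity in this test and lower numbers for higher toxicity in this test. Only compound 3 carries a number, 539000 nM. Compound 1 and compound 2 have no reported result, so compound 3 cannot yet be ranked against either of them.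

The next compound to be tested is compound 4 `COC(=O)CCOc1c2cc([N+](=O)[O-])ccc2nn1Cc1ccccc1`. It keeps the shared core and alters only the end of the chain: methoxycarbonyl in place of bromomethyl on a saturated chain carbon, two bonds along the chain from an oxygen on an aromatic ring. Methoxycarbonyl takes the place of bromomethyl on a saturated chain carbon, two bonds along the chain from an oxygen on an aromatic ring, so 3-bromopropoxy becomes 2-(methoxycarbonyl)ethoxy.

Among the measured compounds shown here, no measured pair shows what this swap does in this assay, so no change beyond the usual scatter is expected, in either direction. For the measured compounds named here, the only anchor is compound 3 at 539000 nM, and the expected step of a 1.1-fold lower number from compound 3 to compound 4 (0.03 log units; within the scatter) is correspondingly small. The half-maximal cytotoxic concentration of compound 4 is estimated at 500000 nM, with an expected range of 150000 nM to 1200000 nM.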

Compound 4, half-maximal cytotoxic concentration: > 300000 nM
Compound 4: no number, only a limit; the forecaster's own chance of this, stated with the estimate: 25%; the middle value is on the limit's open side.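

Compound 4 gave a limit rather than a number, so the size of the change on going from compound 3 to compound 4 cannot be read: the limit of > 300000 nM in this assay, at which 1 of the 4 values shown sits.

The compounds shown leave open whether methoxycarbonyl in place of bromomethyl changes the half-maximal cytotoxic concentration in this assay at all, and in which direction.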